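The source may report more compounds than this note shows. Statements on the series, on what has been measured and on what is new or still open speak of the compounds shown alone.

Measured in a physicochemical assay for lipophilicity, read by HPLC, measured as chromatographic lipophilicity, at pH 7.4; on this read-out higher numbers stand for higher lipophilicity and lower numbers for lower lipophilicity:
- compound 1 `COc1cccc(NC(=O)c2nnn(CC3CCNCC3)c2N)c1`: 0.6
- compound 2 `COc1cccc(NC(=O)c2nnn(CC3CCN(C(=O)OC(C)(C)C)CC3)c2N)c1`: 2.9
- compound 3 `COc1cccc(NC(=O)c2nnn(Cc3ccc(-n4cccn4)cc3)c2N)c1`: 2.4

Compound 1, at 0.6, stands lowest of the three, and both other compounds lie beyond the scatter from it. The change to compound 4 `COc1cccc(NC(=O)c2nnn(Cc3ccc(C4CC4)cc3)c2N)c1` is 4-cyclopropylphenyl in place of piperidin-4-yl on a saturated chain carbon bound to an aromatic nitrogen. Within the data shown here, no measured step covers this exact replacement. The nearest is a number 2.30 log units higher from compound 1 to compound 2 (beyond the scatter), a large step in which tert-butoxycarbonyl takes the place of hydrogen on an amine nitrogen in a ring. Compound 3 also has no piperidin-4-yl and stands at 2.4, clearly higher than compound 1. Both comparisons point the same way, so a large upward step in this assay is expected, of roughly the size seen with compound 2. Among the measured compounds shown here, this remains an expectation, since no measured compound carries 4-cyclopropylphenyl. The expected change is a number 2.50 log units higher from compound 1 to compound 4 (beyond the scatter). The estimate for compound 4 is 3.1, with an expected range from 2.6 to 3.6.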

Compound 4, distribution coefficient: 3.2
Compound 4: the middle estimate sits 0.10 log units below what was measured; the range from low to high includes it.
By their numbers in this assay, from the lowest: compound 1; then compound 3; then compounds 2 and 4 (each within the scatter of the next).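

Replacing piperidin-4-yl on a saturated chain carbon bound to an aromatic nitrogen with 4-cyclopropylphenyl gives, in this assay, a number 2.60 log units higher from compound 1 to compound 4 (beyond the scatter), so this place tolerates a large rise in the number through a group with no hetero atom, and not only through the tert-butoxycarbonyl cap on the ring nitrogen. The group on the aromatic carbon also matters, since cyclopropyl in place of 1H-pyrazol-1-yl gives a number 0.80 log units higher from compound 3 to compound 4 (beyond the scatter) with the rest of the molecule unchanged. Nothing at hand explains either step.

The compounds shown leave open how much of the large step comes from the ring and how much from the cyclopropyl, which an unsubstituted phenyl would separate. As far as these compounds go, how a carboxylic acid or an amine on that aromatic carbon would read in this assay also remains open.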